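The source may hold more compounds than are shown below. What is called first, only, known or untested is meant among the compounds shown, and "the series" means these compounds.

Measured so far:
Compound 1, `COc1ccc(/C=C/C(=O)c2ccc(NC(=O)C(C)O[N+](=O)[O-])cc2)cc1`, gives 35% in a functional assay on the whole organism (strain albino) for inhibition, with Rattus norvegicus as the target, read by paw edema, with stated times of 30 min and 5 h, at a dose of 100 mg/kg by the oral route; on this read-out lower numbers stand for less inhibition and higher numbers for more inhibition at the one dose given (going by the name of the read-out).
Compound 2, `CC(O[N+](=O)[O-])C(=O)Nc1ccc(C(=O)/C=C/c2ccco2)cc1`, gives 49% in this assay.
Compound 3, `COc1ccc(/C=C/C(=O)c2ccc(NC(=O)COc3ccc(C(C)=O)cc3)cc2)cc1`, gives 30% in this assay.

Compounds 1 and 2 share a core and differ in one place: furan-2-yl in place of 4-methoxyphenyl on a double-bonded chain carbon bound to a double-bonded chain carbon. This change gave a number 14 percentage points higher from compound 1 to compound 2 (beyond the scatter), a step that goes beyond the usual scatter of repeated measurements.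

Compound 3 carries a different core; the difference between the core of compound 1 and the core of compound 3 is not broken down here. Among the three measured compounds, compound 3 has the lowest number, but its gap to compound 1 lies within the scatter, so the two cannot be ranked against each other; only its gap to compound 2 is beyond the scatter.

Compound 4, `CC(=O)c1ccc(OCC(=O)Nc2ccc(C(=O)/C=C/c3ccco3)cc2)cc1`, has not yet been measured. It differs from compound 3 in one place: furan-2-yl in place of 4-methoxyphenyl on a double-bonded chain carbon bound to a double-bonded chain carbon. The place is the same as in the step between compounds 1 and 2, so this is the same change, now made on the core of compound 3.

Compound 4 is expected to give 44% in this assay, with a likely range from 30% to 58%. Among the measured compounds shown here, this estimate means a step of a number 14 percentage points higher from compound 3 to compound 4 (beyond the scatter), set to match the earlier step in size because a number 14 percentage points higher from compound 1 to compound 2 (beyond the scatter) is the only measured example of this change. The expectation rests on compound 1 and compound 2 alone; how far the change carries over to a different core cannot be judged from these compounds.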

Compound 4, a percentage reported as inhibition, in the whole organism at one dose (the size of the read-out at that dose, not a potency): 36%
Compound 4: middle estimate off by 8 percentage points, on the high side, and the stated range covers the measured number.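

Putting furan-2-yl in place of 4-methoxyphenyl on the core of compound 3 gave a number 6 percentage points higher from compound 3 to compound 4 (within the scatter) in this assay, so on this core the effect of the change cannot be told apart from the ordinary spread of repeated measurements. Set beside the earlier example of the same change, the two steps do not differ by more than that spread allows: the same change on two cores in this assay, a number 14 percentage points higher (beyond the scatter) from compound 1 to compound 2 and a number 6 percentage points higher (within the scatter) from compound 3 to compound 4, 8 percentage points apart, within the scatter of two such steps. The data therefore do not show that the core alters what this change does, but they also do not show that the change carries over at full size, since one step stands beyond the scatter and the other within it, and two pairs are too few to settle the matter.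

The compounds shown leave open whether the result is particular to furan-2-yl or would also hold for other rings in this place, such as thiophen-2-yl or a plain phenyl. They also leave open how the change behaves on cores with another end to the amide chain, for instance an amine, a carboxylic acid or a longer chain, and a third pair of this kind would give a firmer view of how well it transfers.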